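The source may hold more compounds than are shown below. What is called first, only, known or untested is meant among the compounds shown, and "the series" means these compounds.

Measured in a functional assay on KBVIN cells (Homo sapiens) for antiproliferative activity, read by sulforhodamine B assay, with a stated time of 3 days; a lower number here means that less compound is needed, a higher number that more compound is needed for the effect:
- compound 1 `CCC1=C(O)c2c(oc(-c3ccc(OC)cc3)cc2=O)C(CC)(CC)C1=O`: 0.68 uM
- compound 2 `CCC1=C(O)c2c(oc(-c3ccc(CBr)cc3)cc2=O)C(CC)(CC)C1=O`: 27.9 uM
- compound 3 `CCC1=C(O)c2c(oc(-c3ccc(C)c(F)c3)cc2=O)C(CC)(CC)C1=O`: 2.95 uM

Of these three, compound 3 holds the middle place in this assay. The number rises by a 4.3-fold higher number from compound 1 to compound 3 (0.64 log units; beyond the scatter), and it falls by a 9.5-fold lower number from compound 2 to compound 3 (0.98 log units; beyond the scatter).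

The next compound is compound 4 `CCC1=C(O)c2c(oc(-c3ccc(OC)c(Cl)c3)cc2=O)C(CC)(CC)C1=O`, which has 3-chloro-4-methoxyphenyl in place of 3-fluoro-4-methylphenyl on an aromatic carbon.

The most relevant measurement is the modest step of a 4.3-fold higher number from compound 1 to compound 3 (0.64 log units; beyond the scatter), since compound 1 also carries a 4-methoxyphenyl group. The large step of a 41-fold higher number from compound 1 to compound 2 (1.61 log units; beyond the scatter) bears less directly, as it replaces methoxy with bromomethyl. For the measured compounds named here, no measured compound carries the 3-chloro group, so its contribution remains open. A modest move towards a lower number is therefore expected, probably not recovering all of the gap to compound 1.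

The expected change is a 2.7-fold lower number from compound 3 to compound 4 (0.43 log units; beyond the scatter).

Compound 4 is estimated at 1.1 uM, with an expected range from 0.35 uM to 3.5 uM.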

Compound 4, concentration for half-maximal effect: 1.37 uM
For compound 4 the middle estimate is 1.2-fold (0.10 log units) below the measured one; the measured number falls inside the stated range.
By their numbers in this assay, from the lowest: compounds 1 and 4 (each within the scatter of the next); then compound 3; then compound 2.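

In this assay, chloro added to the 4-methoxyphenyl group on the shared core makes no measurable difference, with a 2.0-fold higher number from compound 1 to compound 4 (0.30 log units; within the scatter), so this position accepts that addition without a change beyond the scatter. The 3-chloro-4-methoxyphenyl group also separates from the other two groups at this position, with a 2.2-fold lower number from compound 3 to compound 4 (0.33 log units; beyond the scatter) and a 20-fold lower number from compound 2 to compound 4 (1.31 log units; beyond the scatter), and the two compounds carrying methoxy on the phenyl ring have the lower numbers of this set. The data shown offer no measurement that explains these differences.

The step to the 3-fluoro-4-methylphenyl group changes both the halogen and the methyl-for-methoxy swap at once, so the share of each stays unresolved. Going by these compounds, whether an ethoxy group, a hydroxyl or an amine in place of the methoxy would keep the number this low also remains open.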